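Trifluoromethyl in place of chloro: notes on compound 4

The source may report more compounds than this note shows. Statements on the series, on what has been measured and on what is new or still open speak of the compounds shown alone.

Measured in a functional assay on A549 cells (Homo sapiens) for antiproliferative activity, read by MTT assay, with a stated time of 48 h; on this read-out higher numbers stand for weaker inhibition and lower numbers for stronger inhibition:
Compound 1 `CCCCCCC1(O)C(=O)Nc2ccc(Nc3ccc(C)cc3)cc21`: 12100 nM
Compound 2 `CC(C)CCC1(O)C(=O)Nc2ccc(Nc3ccc(Cl)cc3)cc21`: 2700 nM
Compound 3 `CCCCCCC1(O)C(=O)Nc2ccc(Nc3ccc(Cl)cc3)cc21`: 5400 nM

Compound 3 cannot be separated from compound 2, as a 2.0-fold higher number from compound 2 to compound 3 (0.30 log units; within the scatter) lies within the scatter. Compound 1 stands clearly higher, with a 2.2-fold lower number from compound 1 to compound 3 (0.35 log units; beyond the scatter) beyond the scatter, though modest.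

The next structure is compound 4 `CCCCCCC1(O)C(=O)Nc2ccc(Nc3ccc(C(F)(F)F)cc3)cc21`, with trifluoromethyl in place of chloro on an aromatic carbon, para to a large group. The nearest evidence is the exchange of methyl for chloro on an aromatic carbon, a 2.2-fold lower number from compound 1 to compound 3 (0.35 log units; beyond the scatter). The chain step, a 2.0-fold higher number from compound 2 to compound 3 (0.30 log units; within the scatter), concerns another part of the molecule and has little bearing here. For the measured compounds named here, no trifluoromethyl compound has been measured, so the direction remains open. In this assay, a small step is expected, probably within the scatter, with only a slight lean towards a lower number. The expected change is a 1.2-fold lower number from compound 3 to compound 4 (0.08 log units; within the scatter). The estimate for compound 4 is 4500 nM, with an expected range of 2000 nM to 10000 nM.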

Compound 4, half-maximal inhibitory concentration: 2800 nM
Estimate against measurement, compound 4: 1.6-fold (0.21 log units) above; measured number inside the range.
By their numbers in this assay, from the lowest: compounds 2, 4 and 3 (each within the scatter of the next); then compound 1.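

At this position, in this assay, the exchange of chloro for trifluoromethyl, with 4 heavy atoms entering where 1 leaves, gives a 1.9-fold lower number from compound 3 to compound 4 (0.29 log units; within the scatter), so the larger group costs no activity and the two substituents cannot be separated. For the compounds shown here, the methyl compound now stands apart from both halogen-bearing groups on the same chain, as the further step gives a 4.3-fold lower number from compound 1 to compound 4 (0.64 log units; beyond the scatter), which extends the single methyl-to-chloro comparison available earlier. No measurement at hand accounts for this difference between methyl and the other two groups.

Still open, going by these compounds, is whether a methoxy, an amine or a carboxylic acid at this position would group with the chloro and trifluoromethyl compounds or with the methyl compound. Also open, on these data alone, is whether trifluoromethyl would keep its standing on the chain of compound 2.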